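The compounds below may be only part of what the source reports. "The series", "measured", "known", "first", "only" and "open" are said of these compounds alone.

Compound 1 `CO[C@H]1CC[C@H](NC(=O)c2n[nH]cc2NC(=O)c2ncoc2-c2ccccc2)CC1`: 28000 nM.
Compound 2 `COc1cccc(OC)c1C(=O)Nc1c[nH]nc1C(=O)NC1CC2CCC1C2`: > 50000 nM.
Compound 3 `CO[C@H]1CC[C@H](NC(=O)c2n[nH]cc2NC(=O)c2ccc(N3CCCC3)cc2)CC1`: > 50000 nM.

All three entries come from an ADME assay on MRC5 cells (Homo sapiens) for inhibition, with a stated time of 72 h; a higher number here means that more compound is needed for the effect, a lower number that less compound is needed. Among the compounds with values here, compound 1 gives the only actual number in the set, 28000 nM. Compound 2 has no number in this assay...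

Corrected notes follow.

Compound 1 `CO[C@H]1CC[C@H](NC(=O)c2n[nH]cc2NC(=O)c2ncoc2-c2ccccc2)CC1`: 28000 nM.
Compound 2 `COc1cccc(OC)c1C(=O)Nc1c[nH]nc1C(=O)NC1CC2CCC1C2`: > 50000 nM.
Compound 3 `CO[C@H]1CC[C@H](NC(=O)c2n[nH]cc2NC(=O)c2ccc(N3CCCC3)cc2)CC1`: > 50000 nM.

All three entries come from this assay. Within the data shown here, compound 1 gives the only actual number in the set. Compound 2 has no number, and its entry of > 50000 nM is a limit of the assay. The entry for compound 3 is the same kind of limit. The set therefore sits largely at one ceiling: the limit of > 50000 nM in this assay, at which 2 of the 3 values shown sit.

Compound 4 `CCCCCNC(=O)c1n[nH]cc1NC(=O)c1c(OC)cccc1OC` is the next compound to be read in this assay. It keeps the rest of compound 2 and changes one group on an amide-type nitrogen: a group of 5 heavy atoms (5 carbon; no ring) in place of a group of 7 heavy atoms (7 carbon; 2 five-membered non-aromatic rings of carbon only), on an amide-type nitrogen. Pentyl, with no ring, thus takes the place of the group carrying 2 five-membered non-aromatic rings of carbon only.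

Among the measured compounds shown here, no measured step isolates a change of this kind, so the expectation rests on the overall spread of the values alone. The expected size is a number no higher from compound 2 to compound 4 (the limit leaves the size open), which means no change beyond the usual scatter and no favoured direction. A report of only a limit is the likelier outcome. For compound 4 the estimated value is 50000 nM, with an expected range from 25000 nM to 100000 nM.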

Compound 4, half-maximal effective concentration: > 50000 nM
Compound 4: no number, only a limit; the forecaster's own chance of this, stated with the estimate: 70%; the middle value lies on the limit itself.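

In this assay compound 4 gives > 50000 nM, which is a limit of the assay. Within the data shown here, compound 2 gives > 50000 nM, also a limit, so no step between compound 2 and compound 4 can be read. The compounds shown leave open how pentyl compares with the group it replaces in this assay, with most values at one ceiling: the limit of > 50000 nM in this assay, at which 3 of the 4 values shown sit.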